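The source may hold more compounds than are shown below. What is called first, only, known or untested is meant among the compounds shown, and "the series" means these compounds.

Measured so far in an assay on microsomes from intestine for inhibition of acyl-CoA:cholesterol acyltransferase (Oryctolagus cuniculus); on this read-out lower numbers stand for stronger inhibition and higher numbers for weaker inhibition:
Compound 1, `O=C(Nc1c(F)cc(F)cc1F)N(Cc1ccc(-c2cccs2)cc1)C1CCCCCC1`: 18 nM
Compound 2, `Cc1cc(C)c(NC(=O)N(Cc2ccc(N3CCN(C)CC3)cc2)C2CCCCCC2)c(C)c1`: 57 nM

Of these two numbers, compound 2 has the higher one, and compound 1 lies a good way below it, beyond the usual scatter. Compound 3, `Cc1cc(C)c(NC(=O)N(Cc2ccc(-c3cccs3)cc2)C2CCCCCC2)c(C)c1`, is not yet measured. It keeps the core of compound 2 and carries thiophen-2-yl in place of 4-methylpiperazin-1-yl on an aromatic carbon. Going by the values given here, no measured pair differs in just this place, so the expectation rests on compound 1, which carries the same thiophen-2-yl and in this assay gives 18 nM. The step is expected to be a 2.3-fold lower number from compound 2 to compound 3 (0.36 log units; beyond the scatter), toward a lower number, beyond the scatter but modest. Compound 3 is estimated at 25 nM, likely between 8 nM and 80 nM.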

Compound 3, half-maximal inhibitory concentration: 22 nM
Estimate against measurement, compound 3: 1.1-fold (0.06 log units) above; the measured number falls inside the stated range.
By their numbers in this assay, from the lowest: compounds 1 and 3 (each within the scatter of the next); then compound 2.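

In this assay, going by these compounds alone, thiophen-2-yl in place of 4-methylpiperazin-1-yl, on an aromatic carbon para to a large group, gives a 2.6-fold lower number from compound 2 to compound 3 (0.41 log units; beyond the scatter) as the first direct reading of this change. Swapping 2,4,6-trifluorophenyl for 2,4,6-trimethylphenyl on the amide-type nitrogen gives a 1.2-fold higher number from compound 1 to compound 3 (0.09 log units; within the scatter), so with thiophen-2-yl in place these two groups cannot be told apart here. Nothing available explains either step. As far as these compounds go, whether a plain phenyl or a morpholine at this position would sit nearer thiophen-2-yl or 4-methylpiperazin-1-yl stays open. So does whether the swap on the amide-type nitrogen would look the same alongside 4-methylpiperazin-1-yl.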